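Chain-length and amine swaps on a dicyano pyrazine core

The compounds below may be only part of what the source reports. "The series", "measured", "known", "first", "only" and "open" are said of these compounds alone.

Three compounds that share one core, with a basic amine on a side chain, were tested in an ADME assay on HEK293 cells (Homo sapiens) for cytotoxicity, read by MTT assay, with a stated time of 48 h; a lower number here means a stronger inhibitor, a higher number a weaker inhibitor. Compound 1 `CCN(CC)CCn1c(N)c(-c2nc3ccccc3[nH]2)c2nc(C#N)c(C#N)nc21` gives 12200 nM. Compound 2 `CN1CCN(CCn2c(N)c(-c3nc4ccccc4[nH]3)c3nc(C#N)c(C#N)nc32)CC1` differs from compound 1 by 4-methylpiperazin-1-yl in place of diethylamino on a saturated chain carbon, two bonds along the chain from an aromatic nitrogen, and in this assay compound 2 gives 10900 nM. Compound 3 `CCN(CC)CCCn1c(N)c(-c2nc3ccccc3[nH]2)c2nc(C#N)c(C#N)nc21` differs from compound 1 by (diethylamino)methyl in place of diethylamino on a saturated chain carbon, two bonds along the chain from an aromatic nitrogen, and in this assay compound 3 gives 7870 nM. The two changes made from compound 1 gave only small steps: a 1.1-fold lower number from compound 1 to compound 2 (0.05 log units; within the scatter) and a 1.6-fold lower number from compound 1 to compound 3 (0.19 log units; within the scatter). Between the other pair, a 1.4-fold lower number from compound 2 to compound 3 (0.14 log units; within the scatter). All three values lie within the scatter of one another, so none can be set apart from the rest.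

Compound 4 `CN1CCN(CCCn2c(N)c(-c3nc4ccccc4[nH]3)c3nc(C#N)c(C#N)nc32)CC1` has not yet been measured in this assay. It differs from compound 3 by 4-methylpiperazin-1-yl in place of diethylamino on a saturated chain carbon, three bonds along the chain from an aromatic nitrogen. This is the same kind of change as that from compound 1 to compound 2, but not the same change, since in compound 1 the substituted carbon sits two bonds along the chain from an aromatic nitrogen, while in compound 3 it sits three bonds along the chain from an aromatic nitrogen. The step is expected to be a 1.1-fold lower number from compound 3 to compound 4 (0.04 log units; within the scatter). This expectation rests on compound 1, where a 1.1-fold lower number from compound 1 to compound 2 (0.05 log units; within the scatter). Compound 4 is therefore estimated at 7200 nM, with a likely range from 3500 nM to 15000 nM.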

Compound 4, half-maximal inhibitory concentration: 6260 nM
Beside the measured number, compound 4's estimate is 1.2-fold (0.06 log units) above it; the range from low to high includes it.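

In this assay, putting 4-methylpiperazin-1-yl in place of diethylamino at the end of the 3-(diethylamino)propyl chain gives a 1.3-fold lower number from compound 3 to compound 4 (0.10 log units; within the scatter). Set beside the same exchange on the 2-(diethylamino)ethyl chain, the result shows that the change carries from one core to the other with no difference that can be told apart: the same change on two cores in this assay, a 1.1-fold lower number (0.05 log units; within the scatter) from compound 1 to compound 2 and a 1.3-fold lower number (0.10 log units; within the scatter) from compound 3 to compound 4, 1.1-fold (0.05 log units) apart, within the scatter of two such steps The two steps that also alter the chain, a 1.7-fold lower number from compound 2 to compound 4 (0.24 log units; within the scatter) and a 1.9-fold lower number from compound 1 to compound 4 (0.29 log units; within the scatter), lie within the scatter as well, so the four compounds show only that no step here stands out, not that the exchange has a real effect of a fixed size, nor that it would behave alike on any further core.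

As far as these compounds go, whether a morpholine or a pyrrolidine at the end of the chain, or a chain longer than the propyl one, would give a step beyond the scatter in this assay remains open. Also open, from the compounds shown here alone, is whether the exchange of diethylamino for 4-methylpiperazin-1-yl would still read the same if the two nitrile groups of the shared core were replaced, for instance by amides.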